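Tert-butylphenyl amide in the pyrazolopyrimidinone series

This account rests on a few compounds, and the source may have more. Where it says the series, first, only, none or still open, it means among the compounds named here.

Measured so far:
compound 1, `CCCCCc1nc2c(-c3ccc(Cl)cc3)n[nH]c2c(=O)n1NC(=O)c1cccc(C)c1`, 88.8%
compound 2, `Cc1cccc(C(=O)Nn2c(CC3CCCCC3)nc3c(-c4ccc(Cl)cc4)n[nH]c3c2=O)c1`, 85.9%

Both measured compounds were tested in a functional assay on DU-145 cells (Homo sapiens) for cytotoxicity, read by sulforhodamine B assay, with a stated time of 2 days, tested at 100 uM; on this read-out lower numbers stand for less inhibition and higher numbers for more inhibition at the one concentration tested (going by the name of the read-out). Compound 1 gives 88.8%, and compound 2 gives 85.9%. Within the data shown here, the only measured step, a number 2.9 percentage points lower from compound 1 to compound 2 (within the scatter), concerns cyclohexyl in place of butyl on a saturated chain carbon bound to an aromatic carbon; the two values lie within the scatter of each other, so compound 2 stands at the same level as compound 1 on these numbers.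

Compound 3, `CC(C)(C)c1ccc(C(=O)Nn2c(CC3CCCCC3)nc3c(-c4ccc(Cl)cc4)n[nH]c3c2=O)cc1`, differs from compound 2 at another place: 4-(tert-butyl)phenyl in place of 3-methylphenyl on a carbonyl carbon. Among the measured compounds shown here, no measured step touches the amide aryl group, so nothing in the data bears directly on this change. Given that the single measured step, a number 2.9 percentage points lower from compound 1 to compound 2 (within the scatter), stayed within the scatter, the estimate for compound 3 assumes a step of a number 3.9 percentage points lower from compound 2 to compound 3 (within the scatter) in this assay, which is expected to remain within the scatter. Compound 3 is therefore expected to give about 82%, in a range from 65% to 95%.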

Compound 3, a percentage reported as inhibition, at one concentration (the size of the read-out at that concentration, not a potency): 65.2%
For compound 3 the middle estimate is 16.8 percentage points above the measured one; measured number inside the range.
By their numbers in this assay, from the lowest: compound 3; then compounds 2 and 1 (each within the scatter of the next).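

In this assay the aryl group on the carbonyl carbon proves to be a place where the number moves (a number 20.7 percentage points lower from compound 2 to compound 3 (beyond the scatter)), while the earlier step at the chain (a number 2.9 percentage points lower from compound 1 to compound 2 (within the scatter)) did not move it beyond the scatter. On this one pair, 4-(tert-butyl)phenyl gives less inhibition at the one concentration tested than 3-methylphenyl, so this position is not indifferent to the group it carries. Nothing at hand accounts for this step.

The change alters both the group and its name-given ring position at once, and 4-methylphenyl or 3-(tert-butyl)phenyl on the same carbonyl carbon would separate the two. Also open, going by these compounds, are how a 4-aminophenyl group would read there, and whether the step holds with butyl in place of cyclohexyl.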